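Series notes: lengthening the chain that carries methylsulfonyl

A few compounds are considered here, and "the series" means these few. Any claim that something is new, unique, unknown or untested is made for them only; others in the source may bear on it.

The series shares one core, drawn out in compound 1 `CCN(CC)CCCn1cc[n+](C)c1/C=N/O` and compound 2 `C[n+]1ccn(CCCS(C)(=O)=O)c1/C=N/O`. In a physicochemical assay for lipophilicity (on this read-out lower numbers stand for lower lipophilicity and higher numbers for higher lipophilicity), compound 1 gives -2.78, and compound 2 gives -2.7. Within the data shown here, the only step measured so far, a number 0.08 log units higher from compound 1 to compound 2 (within the scatter), swapped methylsulfonyl for diethylamino on a saturated chain carbon, three bonds along the chain from an aromatic nitrogen, and left the read-out where it was. On the two numbers available, compound 2 stands together with compound 1; neither is set apart from the other.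

Compound 3 `C[n+]1ccn(CCCCS(C)(=O)=O)c1/C=N/O` is not yet measured. It differs from compound 2 by (methylsulfonyl)methyl in place of methylsulfonyl on a saturated chain carbon, three bonds along the chain from an aromatic nitrogen. Among the measured compounds shown here, the one measured step concerns a swap of group rather than chain length, so it bears only loosely on this change. An upward step is nonetheless expected in this assay, a number 0.25 log units higher from compound 2 to compound 3 (within the scatter). Compound 3 is estimated at -2.45, with a range from -2.9 to -2.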

Compound 3, distribution coefficient: -3.4
Beside the measured number, compound 3's estimate is 0.95 log units above it; the measured number lies below the stated range.
By their numbers in this assay, from the lowest: compound 3; then compounds 1 and 2 (each within the scatter of the next).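

In this assay, this position now shows a real response: (methylsulfonyl)methyl in place of methylsulfonyl, on a saturated chain carbon, three bonds along the chain from an aromatic nitrogen, gives a number 0.70 log units lower from compound 2 to compound 3 (beyond the scatter), whereas the earlier swap of group gave only a number 0.08 log units higher from compound 1 to compound 2 (within the scatter). Compound 3 also stands apart from the diethylamino compound, with a number 0.62 log units lower from compound 1 to compound 3 (beyond the scatter), so the read-out at this position is not flat across the groups shown. Nothing available accounts for the direction of this step.

The compounds shown leave open whether a longer chain ending in methylsulfonyl would continue this downward step or reverse it. Also open, from the compounds shown here alone, is whether the same change behaves alike with another end group, such as diethylamino on a longer chain or a carboxylic acid.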